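A few compounds are considered here, and "the series" means these few. Any claim that something is new, unique, unknown or untested is made for them only; others in the source may bear on it.

Working notes on the series. In a functional assay on HeLa cells (Homo sapiens) for antiproliferative activity, read by MTT assay, with a stated time of 72 h (on this read-out higher numbers stand for weaker inhibition and lower numbers for stronger inhibition), compound 1 (`COc1ccc(-c2ncnn2-c2cc(OC)c(OC)c(OC)c2)cc1`) gives 280 nM as its reading. Compound 2 (`COc1cc(-n2ncnc2-c2ccc(Cl)c(Cl)c2)cc(OC)c1OC`) gives > 10000 nM and this is a limit of the assay, not a number. Going by the values given here, compound 2 therefore has no exact place on the scale, and the series so far shows the limit of > 10000 nM in this assay, at which 1 of the 2 values shown sits, as the only mark for it.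

Compound 3 (`COc1cc(-n2ncnc2-c2cccc(Cl)c2)cc(OC)c1OC`) follows from compound 2 by hydrogen in place of chloro on an aromatic carbon of the same aryl group, ortho to a chloro group and para to a large group, so 3,4-dichlorophenyl becomes 3-chlorophenyl.

Among the compounds with values here, one measured step bears on this: an at least 35-fold higher number from compound 1 to compound 2 (1.55 log units; beyond the scatter) on the same aryl group. That step was large, but it exchanged the whole substituent pattern, and no measurement separates the two chloro groups. On the strength of an at least 35-fold higher number from compound 1 to compound 2 (1.55 log units; beyond the scatter) only a partial return towards lower numbers in this assay is expected, and compound 3 may well stay weak.

The expected change is an at least 3.3-fold lower number from compound 2 to compound 3 (0.52 log units; beyond the scatter) by this estimate. For compound 3 the estimated value is 3000 nM with an expected range of 400 nM to 15000 nM in this read-out.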

Compound 3, half-maximal inhibitory concentration: > 10000 nM
Compound 3: only a limit was reported; the forecaster's own chance of this, stated with the estimate: 40%; at least 3.3-fold (0.52 log units) between middle value and limit.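

In this assay compound 3 gives > 10000 nM, which is a limit of the assay, and the step to it from compound 2 cannot be read, since both compounds sit at a limit. Removing the chloro group ortho to the remaining one therefore brings no reading back onto the scale, and the loss does not require the 3,4-dichlorophenyl pattern, as a single chloro group leaves the same gap to the 4-methoxyphenyl compound: an at least 35-fold higher number from compound 1 to compound 3 (1.55 log units; beyond the scatter). The weak end of the series now rests on a shared mark rather than on exact values: the limit of > 10000 nM in this assay, at which 2 of the 3 values shown sit.

As far as these compounds go, how far compound 2 and compound 3 differ, and how far either lies past the limit, remains unknown, so the contribution of the departing chloro group stays unresolved. Also open, from the compounds shown here alone, is whether the reading of compound 1 rests on the 4-methoxy group specifically, a question that a plain phenyl, a 4-hydroxyphenyl or a 4-aminophenyl group on the same core would address.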